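The source may report more compounds than this note shows. Statements on the series, on what has been measured and on what is new or still open speak of the compounds shown alone.

Measured so far:
- compound 1, `NC(N)=NC(=O)c1nc(Cl)c(NC2CC2)nc1N`: "not determined" (no result reported) in an assay for inhibition of acid-sensing ion channel 3 (Homo sapiens), read by patch clamp, tested at 1 uM; a lower number here means less inhibition, a higher number more inhibition at the concentration tested (going by the name of the read-out)
- compound 2, `NC(N)=NC(=O)c1nc(Cl)c(NC2CCCCC2)nc1N`: 21%

Compound 1 carries a cyclopropyl on the ring nitrogen, but for it no number was obtained in this assay, so nothing can be said of its behaviour. Among the compounds with values here, compound 2 is therefore the only compound with a figure: in this assay compound 2 gives 21%, a modest inhibition at the concentration tested, and it stands alone, with no second number to rank it against.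

The step to compound 3, `NC(N)=NC(=O)c1nc(Cl)c(Nc2cccc(Cl)c2)nc1N`, is a single change on the shared core: 3-chlorophenyl in place of cyclohexyl on a nitrogen on an aromatic ring. Within the data shown here, no measured pair shows what such a change does here, so any expectation rests on compound 2 alone.

Going from a saturated ring to an aromatic one of similar size, a moderate rise is expected, the step of a number 15 percentage points higher from compound 2 to compound 3 (beyond the scatter) being larger than the usual scatter but far from a complete block. In this assay compound 3 is thus estimated at 36%, within a range from 12% to 65%.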

Compound 3, a percentage reported as inhibition, at one concentration (the size of the read-out at that concentration, not a potency): 47%
Compound 3: the middle estimate sits 11 percentage points below what was measured; measured number inside the range.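

Within the data shown here, the exchange gives the first measured pair at this position and shows that the group on the nitrogen on an aromatic ring affects the read-out in this assay: with 3-chlorophenyl in place of cyclohexyl, the result is a number 26 percentage points higher from compound 2 to compound 3 (beyond the scatter). The position therefore accepts an aromatic ring carrying chlorine without any loss of inhibition, although compound 3, at 47%, still gives only partial inhibition at the concentration tested. Nothing available explains why this exchange raises the read-out.

The change alters two things at once, the saturated ring becoming aromatic and a chlorine entering, so the compounds shown cannot say which of the two goes with the rise, a question that a plain phenyl on the same nitrogen would address. Also open, on these data alone, are whether a methoxy or a nitrile in place of the chlorine would give a similar read-out and whether ring size matters among the saturated rings, since compound 1, with its cyclopropyl, stands at "not determined" (no result reported) and offers no comparison.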